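Ester in place of acid on the side chain of compound 1

The source may report more compounds than this note shows. Statements on the series, on what has been measured and on what is new or still open speak of the compounds shown alone.

Measured so far:
compound 1, `COc1ccc(-c2oc3c(CC=C(C)C)c(OC/C=C/C(=O)O)cc(O)c3c(=O)c2O)cc1`: 11300 nM
compound 2, `COc1ccc(-c2oc3c(CC=C(C)C)c(OC/C=C/C(=O)O)cc(O)c3c(=O)c2OC/C=C/C(=O)O)cc1`: 57500 nM

Among the measured compounds shown here, compound 1 holds the lowest of the two numbers in a functional assay on MDA-MB-435S cells (Homo sapiens) for cytotoxicity, read by MTT assay; on this read-out higher numbers stand for weaker inhibition and lower numbers for stronger inhibition; compound 2 sits a 5.1-fold higher number from compound 1 to compound 2 (0.71 log units; beyond the scatter) away, the only measured step. That step adds a 3-carboxyprop-2-en-1-yl group at a second oxygen on the core of compound 1 and leaves the existing side chain untouched.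

Compound 3, `CCOC(=O)COc1cc(O)c2c(=O)c(O)c(-c3ccc(OC)cc3)oc2c1CC=C(C)C`, goes a different way: ethoxycarbonyl in place of 2-carboxyethenyl on a saturated chain carbon bound to an oxygen on an aromatic ring. The chain keeps its attachment to the oxygen on the aromatic ring and its length; what changes is the end of that chain. For the measured compounds named here, no measured step bears directly on this change, since the step from compound 1 to compound 2 concerns a different oxygen and an addition rather than an exchange. The expectation therefore rests on the size of that step alone, which was modest.

Compound 3 is expected to stay close to compound 1 in this assay, with a step of about a 1.1-fold higher number from compound 1 to compound 3 (0.03 log units; within the scatter), not clearly beyond the scatter in either direction. The estimate for compound 3 is 12000 nM, within a range from 4000 nM to 40000 nM.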

Compound 3, half-maximal inhibitory concentration: 5300 nM
Estimate against measurement, compound 3: 2.3-fold (0.35 log units) above; the measured number falls inside the stated range.
By their numbers in this assay, from the lowest: compound 3; then compound 1; then compound 2.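

In this assay, among the compounds shown here, the exchange of 2-carboxyethenyl for ethoxycarbonyl gives a 2.1-fold lower number from compound 1 to compound 3 (0.33 log units; beyond the scatter) and is the first step toward a lower number, so the end of this side chain, left untouched in compound 2, is itself a place where the number moves. The change is modest and beyond the scatter, and it shows that the free carboxylic acid on this chain is not needed to hold the number at the level of compound 1 in this assay. The two groups match in heavy atoms, but the acid and the chain double bond leave together, and no data on the compounds' properties or on any other cause accompany the step.

Which of these two differences carries the step stays open, and a carboxylic acid on the (ethoxycarbonyl)methyl chain in place of its ester, or an ethyl ester on the 3-carboxyprop-2-en-1-yl chain, would separate them. How far the position tolerates other chain ends, such as an amide, an amine or a longer alkyl ester, also remains unsettled.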